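The source may report more compounds than this note shows. Statements on the series, on what has been measured and on what is new or still open speak of the compounds shown alone.

Measured compounds in a functional assay on ZR-75-1 cells (Homo sapiens) for cytotoxicity, read by MTT assay, with a stated time of 72 h; a higher number here means that more compound is needed for the effect, a lower number that less compound is needed:
Compound 1 `CCc1cccc2c(OC)c(-c3occ(C)c3C(=O)OC)ccc12` gives 1.3 ug/mL.
Compound 2 `CCc1cccc2c(OC)c(-c3occ(C)c3C(=O)NC)ccc12` gives > 10 ug/mL, which is a limit of the assay, not a number.
Compound 3 `CCc1cccc2c(OC)c(-c3occ(C)c3CO)ccc12` gives > 10 ug/mL, again a limit of the assay rather than a number.

Compound 3 therefore stands at the weak end of what is shown: it sits at the limit of > 10 ug/mL in this assay, at which 2 of the 3 values shown sit, and only compound 1 has a readable number. The step from compound 1 to compound 3 was an at least 7.6-fold higher number from compound 1 to compound 3 (0.88 log units; beyond the scatter), and the step from compound 1 to compound 2 was an at least 7.6-fold higher number from compound 1 to compound 2 (0.88 log units; beyond the scatter); the step from compound 2 to compound 3 is a step that the two limits leave unreadable from compound 2 to compound 3.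

Compound 4 `CCc1cccc2c(OC)c(-c3occ(C)c3COC)ccc12` differs from compound 3 by methyl in place of hydrogen on an oxygen on a saturated carbon. Among the measured compounds shown here, no measured step covers this exact change, so the expectation rests loosely on compound 1, whose methyl-capped oxygen went with the one readable value, 1.3 ug/mL. Compound 4 is therefore expected to give 8 ug/mL, within 2.5 ug/mL to 25 ug/mL, with the step from compound 3 to compound 4 expected to be an at least 1.2-fold lower number from compound 3 to compound 4 (0.09 log units; that floor lies within the scatter).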

Compound 4, concentration for half-maximal effect: 9.7 ug/mL
The estimate for compound 4 lay 1.2-fold (0.08 log units) below the measured number; low and high end bracket the measured number.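

In this assay, a methyl on the oxygen of the hydroxymethyl group gives an at least 1.0-fold lower number from compound 3 to compound 4 (0.01 log units; that floor lies within the scatter), and methoxymethyl in place of methylcarbamoyl gives an at least 1.0-fold lower number from compound 2 to compound 4 (0.01 log units; that floor lies within the scatter), so neither change shows a gain beyond the scatter. The methoxy oxygen without the carbonyl also does not restore the level of the ester, with a 7.5-fold higher number from compound 1 to compound 4 (0.87 log units; beyond the scatter). Compound 4 adds a readable number at the weak end of the series, while compounds 2 and 3 stay at a limit of the assay: the limit of > 10 ug/mL in this assay, at which 2 of the 4 values shown sit.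

Those limits leave open how far compounds 2 and 3 actually lie from compound 4. Also open, on these data alone, is how an ethyl ester, a carboxylic acid or a longer chain on the oxygen would read on this same aromatic carbon.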